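The source may hold more compounds than are shown below. What is called first, only, known or untested is meant among the compounds shown, and "the series" means these compounds.

In a functional assay on cells (Melanoma cell, Homo sapiens) for cytotoxicity, read by sulforhodamine B assay, with a stated time of 48 h (on this read-out lower numbers stand for stronger inhibition of growth and higher numbers for weaker inhibition of growth), compound 1, `COc1ccc(OC)c(-c2cc(-c3ccc(Cl)cc3)nn2-c2ccc(S(=O)(=O)NC(C)=O)cc2)c1`, gives 10700 nM, and compound 2, `NS(=O)(=O)c1ccc(-n2nc(-c3ccc(Cl)cc3)cc2-c2cc(O)ccc2O)cc1`, gives 14600 nM; the number for compound 2 sits within the scatter of that for compound 1, so the two cannot be put in order. Compound 3, `CC(=O)NS(=O)(=O)c1ccc(-n2nc(-c3ccc(Cl)cc3)cc2-c2cc(O)ccc2O)cc1`, carries acetyl in place of hydrogen on a sulfonamide nitrogen relative to compound 2. For the measured compounds named here, no pair of measured compounds shows this change on its own, so its size in this assay cannot be read from the data, and a step of no more than the scatter, in either direction, is expected for a 1.2-fold lower number from compound 2 to compound 3 (0.09 log units; within the scatter). Compound 3 is therefore estimated at 12000 nM, with a range from 5000 nM to 30000 nM.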

Compound 3, concentration for 50% growth inhibition: 36200 nM
Compound 3: the middle estimate sits 3.0-fold (0.48 log units) below what was measured; the measured number lies above the stated range.
By their numbers in this assay, from the lowest: compounds 1 and 2 (each within the scatter of the next); then compound 3.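

In this assay, for the compounds shown here, acetyl in place of hydrogen on a sulfonamide nitrogen gives a 2.5-fold higher number from compound 2 to compound 3 (0.39 log units; beyond the scatter) and is the first step here beyond the scatter, showing that the measured number responds to a change at this nitrogen. With acetyl on that nitrogen, 2,5-dihydroxyphenyl in place of 2,5-dimethoxyphenyl on an aromatic carbon gives a 3.4-fold higher number from compound 1 to compound 3 (0.53 log units; beyond the scatter) and shows that this second position also registers a change. No available measurement bears on the cause of either step.

Going by these compounds, whether acetyl has the same effect alongside 2,5-dimethoxyphenyl remains open. So does how a longer acyl chain, a methyl group or a carboxylic acid on the sulfonamide nitrogen would compare.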